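The source may report more compounds than this note shows. Statements on the series, on what has been measured and on what is new or still open speak of the compounds shown alone.

Working notes on a series built on a shared core. Compound 1 `CC#CCn1c(N2CCC[C@@H](N)C2)nc2c1c(=O)n(Cc1c(Br)cccc1C(=O)O)c(=O)n2C` carries a 2-bromo-6-carboxyphenyl on a saturated chain carbon bound to an aromatic nitrogen. In an ADME assay on isolated protein for inhibition of Dipeptidyl peptidase 9 (Homo sapiens), with stated times of 15 min, 60 s and 20 min (on this read-out lower numbers stand for stronger inhibition and higher numbers for weaker inhibition), compound 1 gives only a limit, > 100000 nM. Compound 2 `CC#CCn1c(N2CCC[C@@H](N)C2)nc2c1c(=O)n(Cc1ccc(Br)cc1C(=O)OC)c(=O)n2C` bears 4-bromo-2-(methoxycarbonyl)phenyl at the same place; in this assay compound 2 likewise reaches only a limit, > 100000 nM. Compound 3 `CC#CCn1c(N2CCC[C@@H](N)C2)nc2c1c(=O)n(Cc1cccc(F)c1C(=O)O)c(=O)n2C` carries 2-carboxy-3-fluorophenyl there; in this assay compound 3 also stops at a limit, > 100000 nM. Compound 3 thus stands with the other two at the limit of > 100000 nM in this assay, at which 3 of the 3 values shown sit, and nothing sets the three apart. The steps among them cannot be read: a step that the two limits leave unreadable from compound 1 to compound 2, a step that the two limits leave unreadable from compound 1 to compound 3 and a step that the two limits leave unreadable from compound 2 to compound 3 are all unreadable, both ends of each resting at the limit. Compound 4 `CC#CCn1c(N2CCC[C@@H](N)C2)nc2c1c(=O)n(Cc1cc(C#N)ccc1C(=O)O)c(=O)n2C` is not yet measured; the change from compound 3 is 2-carboxy-5-cyanophenyl in place of 2-carboxy-3-fluorophenyl on a saturated chain carbon bound to an aromatic nitrogen. Among the measured compounds shown here, no measured step resolves how this substitution acts, and the three neighbours give no footing for a number beyond the limit. Compound 4 is therefore expected to return only a limit again. The estimate for compound 4 in this assay is 200000 nM, with a range from 50000 nM to 1000000 nM. This corresponds to an expected step that the limit leaves unreadable from compound 3 to compound 4, which in practice is expected to remain unreadable.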

Compound 4, half-maximal inhibitory concentration: > 100000 nM
Compound 4: a limit, no number; the forecaster's own chance of this, stated with the estimate: 85%; the middle value lies beyond the limit too.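

Among the compounds shown here, compound 4 also returns only a limit in this assay, so no step from compound 1, compound 2 or compound 3 to compound 4 can be read, and the series remains unresolved: the limit of > 100000 nM in this assay, at which 4 of the 4 values shown sit. The compounds shown leave open whether any group at this place gives a readable value and how such groups compare.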